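This account rests on a few compounds, and the source may have more. Where it says the series, first, only, none or still open, it means among the compounds named here.

Compound 1, with the structure `Cn1ncc2cc(-c3ccc4oc(NC5CCCCC5)nc4c3)ccc21`, is one of two compounds built on the same atoms joined in different ways. In an assay on HEK293 cells for inhibition of Fatty-acid amide hydrolase 1 (Homo sapiens), read by fluorescence (a higher number here means a weaker inhibitor, a lower number a stronger inhibitor), compound 1 gives 61 nM. Its counterpart compound 2, with the structure `Cn1ncc2c(-c3ccc4oc(NC5CCCCC5)nc4c3)cccc21`, gives 52 nM in this assay; the difference between the two cores is not broken down here, and the two values lie within the scatter of each other.

Compound 3, with the structure `Cn1ncc2cc(-c3ccc4oc(N5Cc6ccccc6C5)nc4c3)ccc21`, keeps the core of compound 1 and carries a group of 9 heavy atoms (8 carbon, 1 nitrogen; one five-membered non-aromatic ring with 1 hetero atom, one six-membered aromatic ring of carbon only) in place of a group of 7 heavy atoms (6 carbon, 1 nitrogen; one six-membered non-aromatic ring of carbon only), on an aromatic carbon. In this assay compound 3 gives 1.2 nM, and the step from its parent is a 51-fold lower number from compound 1 to compound 3 (1.71 log units; beyond the scatter).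

Compound 4, with the structure `Cn1ncc2c(-c3ccc4oc(N5Cc6ccccc6C5)nc4c3)cccc21`, is not yet measured. It carries the same change on the core of compound 2, namely (a group of 9 heavy atoms (8 carbon, 1 nitrogen; one five-membered non-aromatic ring with 1 hetero atom, one six-membered aromatic ring of carbon only) in place of a group of 7 heavy atoms (6 carbon, 1 nitrogen; one six-membered non-aromatic ring of carbon only), on an aromatic carbon), at the same place. Within the data shown here, the step is expected to be a 43-fold lower number from compound 2 to compound 4 (1.64 log units; beyond the scatter), because a 51-fold lower number from compound 1 to compound 3 (1.71 log units; beyond the scatter) is the only measured example of this change. On that basis compound 4 is estimated to give 1.2 nM in this assay, with a likely range from 0.4 nM to 4 nM.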

Compound 4, half-maximal inhibitory concentration: 3.2 nM
For compound 4 the middle estimate is 2.7-fold (0.43 log units) below the measured one, and the stated range covers the measured number.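

On the core of compound 2 the change away from cyclohexylamino again gives a large shift in this assay, a 16-fold lower number from compound 2 to compound 4 (1.21 log units; beyond the scatter), so the direction of the step seen on the core of compound 1 holds on both cores. The size of the step, however, does not carry over unchanged: the same change on two cores in this assay, a 51-fold lower number (1.71 log units; beyond the scatter) from compound 1 to compound 3 and a 16-fold lower number (1.21 log units; beyond the scatter) from compound 2 to compound 4, 3.1-fold (0.50 log units) apart, beyond the scatter of two such steps These two pairs show that the change can be moved between these two cores with a large gain kept, but they offer no rule for other cores and do not explain why the two steps differ.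

The entering group differs from cyclohexylamino both in its rings and in having no hydrogen-bond donor, and the compounds shown do not separate these two differences. Also open, on these data alone, is how smaller or simpler amines at the same place would compare, such as dimethylamino, or a pyrrolidine without the fused aromatic ring.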